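The source may hold more compounds than are shown below. What is called first, only, known or untested is meant among the compounds shown, and "the series" means these compounds.

Within the data shown here, in an assay on the whole organism (plasma, strain Sprague-Dawley) for inhibition of Dipeptidyl peptidase 4 (Rattus norvegicus), with a stated time of 6 h, at a dose of 1 mg/kg by the oral route (on this read-out higher numbers stand for more inhibition at the one dose given (going by the name of the read-out) and lower numbers for less inhibition), compound 1 `CN(C)C(=O)C[C@@H]1CN[C@H](C(=O)N2CCC[C@H]2C#N)C1` gives 66%, the lower of the two numbers measured so far; compound 2 `C[C@@H]1N[C@H](C(=O)N2CCC[C@H]2C#N)C[C@@H]1C(=O)N1CCC1` gives 94%, a difference that lies beyond the usual scatter. The change from compound 1 to compound 3 `N#C[C@@H]1CCCN1C(=O)[C@@H]1C[C@H](C(N)=O)CN1` is carbamoyl in place of (dimethylcarbamoyl)methyl on a saturated ring carbon. Among the measured compounds shown here, no measured pair shows this change on its own, so its effect cannot be read from the data. The expected step of a number 6 percentage points lower from compound 1 to compound 3 (within the scatter) is small and within the scatter. Compound 3 is therefore estimated at 60%, with a range from 40% to 80%.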

Compound 3, a percentage reported as inhibition, in the whole organism at one dose (the size of the read-out at that dose, not a potency): 47%
Beside the measured number, compound 3's estimate is 13 percentage points above it, and the stated range covers the measured number.
By their numbers in this assay, from the lowest: compound 3; then compound 1; then compound 2.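

Among these compounds, this is the first direct reading of a change at this saturated ring carbon: in this assay, carbamoyl in place of (dimethylcarbamoyl)methyl gives a number 19 percentage points lower from compound 1 to compound 3 (beyond the scatter), so inhibition at the one dose depends on the group held here. The swap shortens the group and adds a hydrogen-bond donor together, and this single step cannot separate the two. Nothing available explains the drop.

From the compounds shown here alone, whether an amine or a carboxylic acid on this carbon would keep inhibition stays open. So does the effect of a methyl link carrying a plain carbamoyl group.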